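The source may hold more compounds than are shown below. What is called first, only, known or untested is meant among the compounds shown, and "the series" means these compounds.

Of the compounds shown here, three have been measured in a functional assay on NCI-H520 cells (Homo sapiens) for inhibition, read by MTT assay, with a stated time of 48 h, tested at 10 uM; a lower number here means less inhibition, a higher number more inhibition at the concentration tested (going by the name of the read-out). Compound 1 `COc1cc(NC(=O)Nc2cc(Nc3ccc(C(C)(C)C)cc3)ncn2)cc(OC)c1` gives 17.5% in this assay and stands lowest of the three. Compound 2 `Cc1cc(F)cc(Nc2cc(NC(=O)Nc3c(Cl)cccc3Cl)ncn2)c1` gives 60.5%, and compound 3 `COc1cc(Nc2cc(NC(=O)Nc3c(Cl)cccc3Cl)ncn2)cc(OC)c1` gives 55.5%; both lie well above compound 1, the gap to compound 3 and the gap to compound 2 each being beyond the usual scatter. Among the measured compounds shown here, compounds 2 and 3 differ from compound 1 in more than one place, so no single step between measured compounds can be read from these three numbers.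

Compound 4 `COc1cc(NC(=O)Nc2cc(Nc3cc(Br)ccc3OC)ncn2)cc(OC)c1` has not yet been measured. It differs from compound 1 as follows: 5-bromo-2-methoxyphenyl in place of 4-(tert-butyl)phenyl on a nitrogen on an aromatic ring. The rest of compound 1 is kept. For the measured compounds named here, with no measured step covering this change, the direction is open; a modest rise seems the more likely outcome given that compound 1 sits at 17.5%, the lowest number seen here, yet a result within the scatter of compound 1 cannot be ruled out. The expected step is a number 12.5 percentage points higher from compound 1 to compound 4 (beyond the scatter). Compound 4 is therefore estimated to give 30% in this assay, with a likely range from 10% to 55%.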

Compound 4, a percentage reported as inhibition, at one concentration (the size of the read-out at that concentration, not a potency): 43.5%
Compound 4: middle estimate off by 13.5 percentage points, on the low side; low and high end bracket the measured number.
By their numbers in this assay, from the lowest: compound 1; then compound 4; then compounds 3 and 2 (each within the scatter of the next).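

In this assay, the group on the nitrogen on an aromatic ring is now shown to matter on its own: with the rest of compound 1 kept, 5-bromo-2-methoxyphenyl in place of 4-(tert-butyl)phenyl gives a number 26 percentage points higher from compound 1 to compound 4 (beyond the scatter). This is the first single change that can be read among these compounds, which the earlier numbers could not provide. Among the compounds shown here, it shows that inhibition at the concentration tested can move with this group alone, though the one step gives no trend across this position.

From the compounds shown here alone, whether the bromine or the methoxy of the entering group carries the rise stays open, as does what a carboxylic acid or a morpholine on that phenyl ring would give, and whether the same exchange would move compound 2 or compound 3 at all. Nothing measured here explains the step.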